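This account rests on a few compounds, and the source may have more. Where it says the series, first, only, none or still open, it means among the compounds named here.

Compound 1 `COc1cccc(OC)c1C(=O)Nc1c[nH]nc1C(=O)Nc1ccncc1` stands at the limit of > 50000 nM in this assay, at which 1 of the 2 values shown sits, a limit of an ADME assay on MRC5 cells (Homo sapiens) for inhibition, with a stated time of 72 h (on this read-out lower numbers stand for an effect already at smaller amounts and higher numbers for an effect only at larger amounts of compound), rather than a number: in this assay compound 1 gives > 50000 nM. Compound 2 `CO[C@H]1CC[C@H](NC(=O)c2n[nH]cc2NC(=O)c2ccc(OC(F)F)cc2)CC1` is the other compound measured; in this assay compound 2 gives 2500 nM. Among the measured compounds shown here, no step between measured compounds that differ in one place is available. Compound 3 `COc1cccc(OC)c1C(=O)Nc1c[nH]nc1C(=O)NCc1ccccn1` differs from compound 1 by (pyridin-2-yl)methyl in place of pyridin-4-yl on an amide-type nitrogen. For the measured compounds named here, with no measured step to lean on, the expected change a number no higher from compound 1 to compound 3 (the limit leaves the size open) is none beyond the scatter. Compound 3 is expected to sit at the limit again and is estimated at 50000 nM, within 20000 nM to 100000 nM.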

Compound 3, half-maximal effective concentration: > 50000 nM
Compound 3 ended at the assay's limit; the forecaster's own chance of this, stated with the estimate: 70%; the middle value lies on the limit itself.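

In this assay, among the compounds shown here, compound 3 gives > 50000 nM, a limit and not a number, as compound 1 does, so no step from compound 1 to compound 3 can be read. The compounds shown leave open whether (pyridin-2-yl)methyl and pyridin-4-yl differ at all on this read-out.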